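The source may report more compounds than this note shows. Statements on the series, on what has been measured and on what is new or still open speak of the compounds shown alone.

Of the compounds shown here, two of one series have so far been tested in a functional assay on SH-SY5Y cells (Homo sapiens) for cytotoxicity, read by MTT assay, with stated times of 8 h, 30 min and 12 h, tested at 0.05 uM; on this read-out lower numbers stand for a weaker effect and higher numbers for a stronger effect at the one concentration tested. Compound 1 `COc1ccc(CNC(=N)[C@@H]2CCC(=O)N2Cc2ccc(F)cc2)cc1` gives 15.8% in this assay, and compound 2 `Cc1ccc(CN2C(=O)CC[C@H]2C(=N)NCc2ccccc2)cc1` gives 17.1%. With only these two numbers available, compound 2 sits within the usual scatter of compound 1, so the two cannot be told apart on this read-out. Compound 3 `COc1ccc(CNC(=N)[C@@H]2CCC(=O)N2Cc2ccc(C)cc2)cc1` has not yet been measured in this assay. It differs from compound 2 in a single place: methoxy in place of hydrogen on an aromatic carbon. Going by the values given here, no measured pair carries this change on its own, so there is no measured step to lean on. Compound 1 already bears the methoxy group and gives 15.8%, which sits close to the number for compound 2. The step is therefore expected to be a number 0.6 percentage points lower from compound 2 to compound 3 (within the scatter), none beyond the scatter. For compound 3 an activity of 16.5% is estimated, with a range from 8% to 26%.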

Compound 3, a percentage reported as activity, at one concentration (the size of the read-out at that concentration, not a potency): 19.5%
Estimate against measurement, compound 3: 3 percentage points below; the measured number falls inside the stated range.
By their numbers in this assay, from the lowest: compounds 1, 2 and 3 (each within the scatter of the next).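

In this assay, methoxy in place of hydrogen on an aromatic carbon, para to a large group, now has a measured step of its own: a number 2.4 percentage points higher from compound 2 to compound 3 (within the scatter) is what the change from phenyl to 4-methoxyphenyl gives, so this change does not separate the two compounds on this read-out. Methyl in place of fluoro on an aromatic carbon also has its first measured step, a number 3.7 percentage points higher from compound 1 to compound 3 (within the scatter), and it does not separate its two compounds either. Nothing measured here bears on why these steps have the size they do.

The compounds shown leave open whether an amine or a carboxylic acid in place of methoxy at this position would give a number beyond the scatter. They also leave open whether a longer chain, such as butoxy, would do so.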